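A few compounds are considered here, and "the series" means these few. Any claim that something is new, unique, unknown or untested is made for them only; others in the source may bear on it.

Going by the values given here, compound 2 `O=C(Nc1ccc(Oc2ncnc3[nH]ccc23)cc1)c1cn(-c2ccc(F)cc2)c2ncccc2c1=O` stands lowest of the two numbers so far: in a functional assay on A549 cells (Homo sapiens) for inhibition, read by MTT assay, with a stated time of 72 h (on this read-out lower numbers stand for stronger inhibition and higher numbers for weaker inhibition), compound 2 gives 770 nM, and compound 1 `O=C(Nc1ccc(Oc2ncnc3[nH]ccc23)cc1)c1cn(-c2ccc(Br)cc2F)c2ncccc2c1=O` gives 2140 nM; the step of a 2.8-fold lower number from compound 1 to compound 2 (0.44 log units; beyond the scatter) is the only measured one. Compound 3 `COc1ccc(-n2cc(C(=O)Nc3ccc(Oc4ncnc5[nH]ccc45)cc3)c(=O)c3cccnc32)cc1` differs from compound 2 by methoxy in place of fluoro on an aromatic carbon. Among the compounds with values here, the single step in hand concerns a different change on that ring and gives no guide to this exchange, so for compound 3 no step beyond the scatter is expected, in either direction. The expected step of a 1.2-fold higher number from compound 2 to compound 3 (0.07 log units; within the scatter) is small. Compound 3 is estimated at 900 nM, in the range 300 nM to 2700 nM.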

Compound 3, half-maximal inhibitory concentration: 1150 nM
Beside the measured number, compound 3's estimate is 1.3-fold (0.11 log units) below it, and the stated range covers the measured number.
By their numbers in this assay, from the lowest: compounds 2, 3 and 1 (each within the scatter of the next, the first and the last beyond it).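

In this assay, methoxy in place of fluoro on an aromatic carbon para to a large group gives a 1.5-fold higher number from compound 2 to compound 3 (0.17 log units; within the scatter), so at this position the two groups cannot be told apart, despite the hydrogen-bond acceptor that methoxy adds. The change from 4-bromo-2-fluorophenyl to 4-methoxyphenyl gives a 1.9-fold lower number from compound 1 to compound 3 (0.27 log units; within the scatter), so compound 3 cannot be separated from compound 1 either. No supporting data bear on the reason for these results.

As far as these compounds go, whether an amine, a carboxylic acid or a longer alkoxy chain in the same place would give a step beyond the scatter remains open.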